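Hydroxamate chain homologation on two aminopyrazolopyrimidine cores

The compounds below may be only part of what the source reports. "The series", "measured", "known", "first", "only" and "open" are said of these compounds alone.

Compound 1 `Nc1ncnc2c1c(-c1cnc3[nH]ccc3c1)nn2CCCCCCCCC(=O)NO` and compound 2 `Nc1ncnc2c1c(-c1cnc3[nH]ccc3c1)nn2CCCCCCCCCC(=O)NO` share one core; compound 3 `Nc1nc2cc(-c3nn(CCCCC(=O)NO)c4ncnc(N)c34)ccc2o1` and compound 4 `Nc1nc2cc(-c3nn(CCCCCC(=O)NO)c4ncnc(N)c34)ccc2o1` share another, and the difference between the two cores is not broken down here. In a functional assay on A549 cells (Homo sapiens) for inhibition, read by MTT assay, with a stated time of 72 h (on this read-out higher numbers stand for weaker inhibition and lower numbers for stronger inhibition), compound 1 gives 12300 nM, and compound 2 gives 6550 nM. The change between them is (hydroxycarbamoyl)methyl in place of hydroxycarbamoyl on a saturated chain carbon, eight bonds along the chain from an aromatic nitrogen, and the step is a 1.9-fold lower number from compound 1 to compound 2 (0.27 log units; within the scatter). Compound 3 reaches only a limit in this assay, > 100000 nM. That is the limit of > 100000 nM in this assay, at which 1 of the 3 values shown sits. The change from compound 3 to compound 4 is (hydroxycarbamoyl)methyl in place of hydroxycarbamoyl on a saturated chain carbon, four bonds along the chain from an aromatic nitrogen, the same kind of change, here four bonds along the chain from an aromatic nitrogen rather than eight. Resting on a 1.9-fold lower number from compound 1 to compound 2 (0.27 log units; within the scatter), the step from compound 3 to compound 4 is expected to be small, an at least 1.4-fold lower number from compound 3 to compound 4 (0.15 log units; that floor lies within the scatter), and may again end at a limit. Compound 4 is estimated at 70000 nM, between 20000 nM and 200000 nM.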

Compound 4, half-maximal inhibitory concentration: > 100000 nM
Compound 4 gave a limit, no number; the forecaster's own chance of this, stated with the estimate: 55%; at least 1.4-fold (0.15 log units) between middle value and limit.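

In this assay, going by these compounds alone, compound 4 gives > 100000 nM, a limit and not a number, and compound 3 also stands at a limit, so no step between them can be read. On these data alone, whether this chain extension changes inhibition on their shared core remains open.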